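This account rests on a few compounds, and the source may have more. Where it says the series, first, only, none or still open, it means among the compounds named here.

Measured so far:
- compound 1, `COc1ccc(N2C(=O)NC3(CSC4=C3C(=O)c3ncccc3C4=O)C2=O)cc1`: 50 nM
- compound 2, `O=C1NNC(=O)C2(CSC3=C2C(=O)c2ncccc2C3=O)N1`: 450 nM

In a functional assay on CCRF-CEM cells (Homo sapiens) for antiproliferative activity, read by MTT assay, with a stated time of 96 h (on this read-out lower numbers stand for stronger inhibition and higher numbers for weaker inhibition), compound 1 gives the lowest of the two numbers, and compound 2 sits a long way behind it, beyond the usual scatter of this kind of measurement. Compound 3, `O=C1C2=C(C(=O)c3ncccc31)C1(CS2)NC(=O)N(c2ccc([N+](=O)[O-])cc2)C1=O`, has not yet been measured. It differs from compound 1 in one place: nitro in place of methoxy on an aromatic carbon. The nitro group enters on an aromatic carbon of a six-membered aromatic ring of carbon only, para to a large group, exactly where the methoxy group left. For the measured compounds named here, no pair of measured compounds shows what such a swap does here, so the direction of the step is open; the expectation is for a small step in this assay, either none beyond the scatter or a mild shift toward weaker inhibition, as a 1.4-fold higher number from compound 1 to compound 3 (0.15 log units; within the scatter) expresses. Compound 3 is therefore expected to give about 70 nM, with a likely range from 15 nM to 300 nM.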

Compound 3, half-maximal inhibitory concentration: 1 nM
Beside the measured number, compound 3's estimate is 70-fold (1.85 log units) above it, outside the stated range (below it).
By their numbers in this assay, from the lowest: compound 3; then compound 1; then compound 2.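

In this assay, changing 4-methoxyphenyl to 4-nitrophenyl gives a 50-fold lower number from compound 1 to compound 3 (1.70 log units; beyond the scatter) on an otherwise unchanged structure. The earlier compounds shown here could not show this, since compound 1 and compound 2 differ in more than one place. Now a single group on an aromatic carbon, para to a large group, is seen to move the number strongly, and nitro is the better of the two groups compared there, though nothing available explains the gain.

With only methoxy and nitro compared at this place, two groups cannot show a trend, so an amine, a nitrile or a carboxylic acid there could fall anywhere. A plain hydrogen in the same place would show whether nitro improves on the bare phenyl ring or methoxy weakens it.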